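An Ethyl for a Methyl on the Ring Amine

A few compounds are considered here, and "the series" means these few. Any claim that something is new, unique, unknown or untested is made for them only; others in the source may bear on it.

Of the compounds shown here, three have been measured in an assay on HeLa cells for displacement of a labelled ligand from 5-hydroxytryptamine receptor 6 (Homo sapiens); a higher number here means a weaker inhibitor, a lower number a stronger inhibitor. Compound 1 `CN1CCC(n2cc(S(=O)(=O)c3cccc(Cl)c3)c3cccnc32)C1` gives 1.5 nM. Compound 2 `CCN1CCC(n2cc(S(=O)(=O)c3cccc(Cl)c3)c3cccnc32)C1` gives 3.3 nM in this assay. Compound 3 `CN1CCCC(n2cc(S(=O)(=O)c3ccc(Cl)cc3)c3cccnc32)C1` gives 11.5 nM in this assay, which places it highest of the three.

The difference between the core of compound 1 and the core of compound 3 is not broken down here. Within the first pair, the change methyl in place of hydrogen on a saturated chain carbon bound to an amine nitrogen in a ring gave a 2.2-fold higher number from compound 1 to compound 2 (0.34 log units; beyond the scatter).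

Compound 4 `CCN1CCCC(n2cc(S(=O)(=O)c3ccc(Cl)cc3)c3cccnc32)C1` is not yet measured. It differs from compound 3 by methyl in place of hydrogen on a saturated chain carbon bound to an amine nitrogen in a ring, the same change that was made from compound 1 to compound 2, and the place of the change is described in the same words for both pairs. The change has been seen only once, so the expectation for compound 4 rests on that single step. Because the step of a 2.2-fold higher number from compound 1 to compound 2 (0.34 log units; beyond the scatter) went toward a higher number, a step of comparable size is expected for compound 4, a 2.1-fold higher number from compound 3 to compound 4 (0.32 log units; beyond the scatter), starting from the higher level of compound 3.

On this basis compound 4 is estimated to give 24 nM in this assay, with an expected range from 10 nM to 55 nM, since the difference between the two cores carries no counted information about how they would respond to the same change.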

Compound 4, inhibition constant: 33.5 nM
Estimate against measurement, compound 4: 1.4-fold (0.14 log units) below, within the range that was stated.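

In this assay, going from methyl to ethyl on the ring amine, that is from 1-methylpiperidin-3-yl to 1-ethylpiperidin-3-yl, gave a 2.9-fold higher number from compound 3 to compound 4 (0.46 log units; beyond the scatter), and this step can now be set beside the earlier one: the same change on two cores in this assay, a 2.2-fold higher number (0.34 log units; beyond the scatter) from compound 1 to compound 2 and a 2.9-fold higher number (0.46 log units; beyond the scatter) from compound 3 to compound 4, 1.3-fold (0.12 log units) apart, within the scatter of two such steps. Across these two pairs, the change moved the number in the same direction and by sizes that cannot be told apart, so in this small set it carried over from one core to the other without a detectable difference in its size. Among these compounds, this does not show that the step would hold on any further core, since it rests on only two pairs in a single assay, and it says nothing about why the number rises or about what separates the levels of the two cores.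

What the compounds shown leave open is whether the number keeps rising along a longer chain on the ring amine, such as propyl or butyl, or whether a branched group such as isopropyl or a cyclopropyl group behaves in the same way. They also leave open how a hydrogen on that amine, with no alkyl group at all, would compare with the methyl compounds on either core.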